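The source may report more compounds than this note shows. Statements on the series, on what has been measured and on what is new or still open speak of the compounds shown alone.

Of the compounds shown here, three built on the same core have been tested in a functional assay on the whole organism (artery, strain albino) with Rattus norvegicus as the target, with a stated time of 360 min, at a dose of 10 mg/kg by the oral route; on this read-out higher numbers stand for more inhibition at the one dose given (going by the name of the read-out) and lower numbers for less inhibition. Compound 1 `COc1ccc(C2N=C(SCc3ccccc3Cl)NC(C)=C2C(=O)Nc2ccc(F)cc2)cc1OC` gives 39.2% in this assay. Compound 2 `COc1ccc(C2N=C(SCc3cccc(Cl)c3)NC(C)=C2C(=O)Nc2ccc(F)cc2)cc1OC` differs from compound 1 in a single place: 3-chlorophenyl in place of 2-chlorophenyl on a saturated chain carbon bound to a sulfur. In this assay, going by the values given here, compound 2 gives 20.1%, and the step of a number 19.1 percentage points lower from compound 1 to compound 2 (beyond the scatter) is the only instance of this change that has been measured. Compound 3 `CC1=C(C(=O)Nc2ccc([N+](=O)[O-])cc2)C(c2cccc([N+](=O)[O-])c2)N=C(SCc2ccccc2Cl)N1` carries a different set of groups around the shared core, and the difference between its core and that of compound 1 is not broken down here. In this assay compound 3 gives 17.5%, which lies close to the value of compound 2 and well apart from that of compound 1.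

Compound 4 `CC1=C(C(=O)Nc2ccc([N+](=O)[O-])cc2)C(c2cccc([N+](=O)[O-])c2)N=C(SCc2cccc(Cl)c2)N1` has not yet been measured. It stands to compound 3 exactly as compound 2 stands to compound 1: 3-chlorophenyl in place of 2-chlorophenyl on a saturated chain carbon bound to a sulfur. The earlier instance of this change lowered inhibition, and the same direction is expected here because of a number 19.1 percentage points lower from compound 1 to compound 2 (beyond the scatter). Since compound 3 already sits low, there is less room to fall, so a smaller downward step is expected: a number 9.5 percentage points lower from compound 3 to compound 4 (within the scatter). Compound 4 is therefore expected to give about 8% in this assay. The expected range for compound 4 runs from -8% to 22%.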

Compound 4, a percentage reported as inhibition, in the whole organism at one dose (the size of the read-out at that dose, not a potency): 21.6%
Compound 4: middle estimate off by 13.6 percentage points, on the low side; the range from low to high includes it.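

In this assay, putting 3-chlorophenyl in place of 2-chlorophenyl on a saturated chain carbon bound to a sulfur gives a number 4.1 percentage points higher from compound 3 to compound 4 (within the scatter), so on this core the change produces no clear shift in the read-out. The change therefore does not carry over unchanged between these two cores, and what it does on one core cannot simply be assumed for the other: the same change on two cores in this assay, a number 19.1 percentage points lower (beyond the scatter) from compound 1 to compound 2 and a number 4.1 percentage points higher (within the scatter) from compound 3 to compound 4, 23.2 percentage points apart, beyond the scatter of two such steps These two pairs do not show which of the groups that differ between compound 1 and compound 3 is responsible for the gap, and they give no rule for predicting the step on a further core.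

The compounds shown leave open whether a compound that differs from compound 1 only in its amide group, or only in the other aromatic group on the shared core, would behave like compound 1 or like compound 3 when this change is made. They also leave open how the read-out responds when the chlorophenyl on the saturated chain carbon bound to a sulfur gives way to a different group, such as an unsubstituted phenyl or a carboxylic acid.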